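Cytotoxicity notes: from compound 3 to compound 4

The source may report more compounds than this note shows. Statements on the series, on what has been measured and on what is new or still open speak of the compounds shown alone.

Compound 3 `O=C(c1ccn(-c2ccc3c(c2)B(O)OC3)c1)C1CCCCC1` stands at the limit of an ADME assay on L929 cells (Mus musculus) for cytotoxicity, read by resazurin assay, with a stated time of 72 h; on this read-out higher numbers stand for weaker inhibition and lower numbers for stronger inhibition: compound 3 gives > 10 ug/mL, a limit and not a number. Compound 1 `O=C(c1ccc(F)cc1)c1ccn(-c2ccc3c(c2)B(O)OC3)c1` likewise gives a limit, > 10 ug/mL. Compound 2 `O=C(c1ccc(CO)cc1)c1ccn(-c2ccc3c(c2)B(O)OC3)c1` gives 9.31 ug/mL in this assay. The step of an at least 1.0-fold higher number from compound 2 to compound 3 (0.03 log units; that floor lies within the scatter) rests on that limit (the limit of > 10 ug/mL in this assay, at which 2 of the 3 values shown sit), and the step that the two limits leave unreadable from compound 1 to compound 3 rests on two limits, so neither is readable in size. Compound 4 `NCCCC(=O)c1ccn(-c2ccc3c(c2)B(O)OC3)c1` differs by 3-aminopropyl in place of cyclohexyl on a carbonyl carbon. For the measured compounds named here, no measured step changes the group on the carbonyl carbon to an open chain, so the steps into compound 3 give only floors within the scatter. The expected step of a number no higher from compound 3 to compound 4 (the limit leaves the size open) is therefore none beyond the scatter. Compound 4 is expected near 10 ug/mL, within 5 ug/mL to 30 ug/mL, most likely reported again as a limit.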

Compound 4, half-maximal inhibitory concentration: > 10 ug/mL
Compound 4: a limit, no number; the forecaster's own chance of this, stated with the estimate: 70%; the middle value sits exactly at the limit.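

On the carbonyl carbon, an open chain carrying an amine, 3-aminopropyl, now joins cyclohexyl and 4-fluorophenyl in giving a limit and not a number in this assay: the limit of > 10 ug/mL in this assay, at which 3 of the 4 values shown sit. The steps to compound 4 from compound 1 and from compound 3 cannot be read. For the compounds shown here, the only other step gives just a floor, an at least 1.0-fold higher number from compound 2 to compound 4 (0.03 log units; that floor lies within the scatter).

Going by these compounds, how far the true values of compound 1, compound 3 and compound 4 lie past the limit stays open. Also open, on these data alone, is whether a carboxylic acid or a longer amine chain on this carbonyl carbon would give a measurable number.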